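Shortening the urea chain: compound 1 to compound 4

The source may hold more compounds than are shown below. What is called first, only, known or untested is meant among the compounds shown, and "the series" means these compounds.

Three compounds share one core and differ only in the substituent on the urea nitrogen. Compound 1 `CCCCNC(=O)N1CC1C#N` carries a butyl chain, compound 2 `CC(=O)c1cccc(NC(=O)N2CC2C#N)c1` an aryl group bearing an acetyl, and compound 3 `N#CC1CN1C(=O)Nc1ccc([N+](=O)[O-])cc1` an aryl group bearing a nitro substituent. In a functional assay on A549 cells (Homo sapiens) for inhibition (on this read-out lower numbers stand for stronger inhibition and higher numbers for weaker inhibition), compound 1 gives 18000 nM, the highest number of the three. Compound 2 gives 5600 nM and compound 3 gives 3900 nM; both steps from compound 1 lie beyond the scatter, so compound 1 is the weakest inhibitor among the three measured.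

Compound 4 `CNC(=O)N1CC1C#N` differs from compound 1 by hydrogen in place of propyl on a saturated chain carbon bound to an amide-type nitrogen. Among the compounds with values here, no measured pair shows this kind of change, so the step has no direct precedent. Given that compound 1 already stands at 18000 nM and that the two aryl ureas are stronger, a further cut of the chain is expected to move the number upward, beyond the scatter, a 2.2-fold higher number from compound 1 to compound 4 (0.35 log units; beyond the scatter). Compound 4 is accordingly estimated at 40000 nM, within 15000 nM to 110000 nM.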

Compound 4, half-maximal inhibitory concentration: 22000 nM
The estimate for compound 4 lay 1.8-fold (0.26 log units) above the measured number; the measured number falls inside the stated range.
By their numbers in this assay, from the lowest: compounds 3 and 2 (each within the scatter of the next); then compounds 1 and 4 (each within the scatter of the next).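

In this assay, within the data shown here, the step from butyl to methyl, hydrogen in place of propyl on a saturated chain carbon bound to an amide-type nitrogen, reads a 1.2-fold higher number from compound 1 to compound 4 (0.09 log units; within the scatter) and is the first single-place comparison. At this place, the loss of propyl leaves the read-out within the scatter, so these two chain lengths are not told apart by this read-out. No supporting measurement bears on this result.

From the compounds shown here alone, whether the flat result holds beyond these two chains remains open: a hexyl chain, or a butyl chain ending in an amine or a carboxylic acid, would test it. A plain phenyl in place of butyl would give a single-place link between the alkyl chains and the substituted aryl groups.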